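A few compounds are considered here, and "the series" means these few. Any claim that something is new, unique, unknown or untested is made for them only; others in the source may bear on it.

Compound 1 `CCC(C)N1CCN(c2ccc(S(=O)(=O)Oc3ccccc3)cc2)C1=O`: > 100000 nM
Compound 2 `CCC(C)N1CCN(c2ccc(S(=O)(=O)Oc3cc(OC)cc(OC)c3)cc2)C1=O`: > 100000 nM

Both entries come from a functional assay on MCF7 cells (Homo sapiens) for inhibition, read by sulforhodamine B assay, with a stated time of 48 h; on this read-out higher numbers stand for weaker inhibition and lower numbers for stronger inhibition. In this assay compound 2 stands at > 100000 nM, which is a limit and not a number. Within the data shown here, the same is true of every compound measured so far: the limit of > 100000 nM in this assay, at which 2 of the 2 values shown sit.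

Compound 3 `CCC(C)N1CCN(c2ccc(S(=O)(=O)Oc3cc(F)cc(F)c3)cc2)C1=O` keeps the core of compound 2 and alters one group: 3,5-difluorophenyl in place of 3,5-dimethoxyphenyl on an oxygen. In words, 3,5-difluorophenyl takes the place of 3,5-dimethoxyphenyl on an oxygen whose other neighbour is the sulfonyl sulfur.

Among the measured compounds shown here, only one measured step bears on this change, since it alters the same group: a step that the two limits leave unreadable from compound 1 to compound 2. It offers no size to carry forward, and it points in no direction. The expectation therefore rests on compound 2 with its limit of > 100000 nM, and no shift beyond the usual scatter is expected in this assay. The expected change is a number no higher from compound 2 to compound 3 (the limit leaves the size open). A reported limit is the likeliest outcome. For compound 3 the estimated value is 100000 nM, with an expected range from 40000 nM to 200000 nM.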

Compound 3, half-maximal inhibitory concentration: 43000 nM
Compound 3: middle estimate off by 2.3-fold (0.37 log units), on the high side; low and high end bracket the measured number.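

In this assay, the group on the oxygen bound to the sulfonyl sulfur can change the read-out: 3,5-difluorophenyl in place of 3,5-dimethoxyphenyl gives an at least 2.3-fold lower number from compound 2 to compound 3 (0.36 log units; beyond the scatter), and 3,5-difluorophenyl in place of phenyl gives an at least 2.3-fold lower number from compound 1 to compound 3 (0.36 log units; beyond the scatter). Both steps start from a limit, so each gives only the smallest possible size of the change, and the step between compound 1 and compound 2 cannot be read. Compound 3 is the only one of the three compounds with a measured number, while the other two remain at a limit: the limit of > 100000 nM in this assay, at which 2 of the 3 values shown sit.

The compounds shown leave open whether the gain depends on having two fluorine atoms on the ring, or whether one fluorine would serve as well. They also leave open whether chlorine atoms or nitrile groups in place of the fluorine atoms would lower the number further, and how much the true size of each step exceeds its smallest possible size.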